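A few compounds are considered here, and "the series" means these few. Any claim that something is new, unique, unknown or untested is made for them only; others in the source may bear on it.

In a functional assay on A549 cells (Homo sapiens) for antiproliferative activity, read by spectrophotometry, with a stated time of 2 days (on this read-out higher numbers stand for weaker inhibition of growth and lower numbers for stronger inhibition of growth), compound 1 `Cc1ccc(Nc2ncc(C(F)(F)F)c(N3Cc4cccc(N(C)S(C)(=O)=O)c4C3)n2)cc1C` gives > 30000 nM, which is a limit of the assay and not a number. Compound 3 `CN(c1cccc2c1CN(c1nc(Nc3cc(C(F)(F)F)cc(C(F)(F)F)c3)ncc1C(F)(F)F)C2)S(C)(=O)=O` gives > 30000 nM, which is also a limit. Compound 2 `CN(c1cccc2c1CN(c1nc(Nc3ccc(Nc4ccccc4)cc3)ncc1C(F)(F)F)C2)S(C)(=O)=O` gives an actual number, 6200 nM. Compound 1 therefore stands with the limit of > 30000 nM in this assay, at which 2 of the 3 values shown sit.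

The next compound to be tested is compound 4 `Cc1cc(Cl)ccc1Nc1ncc(C(F)(F)F)c(N2Cc3cccc(N(C)S(C)(=O)=O)c3C2)n1`. It keeps the core of compound 1 and puts 4-chloro-2-methylphenyl in place of 3,4-dimethylphenyl on a nitrogen on an aromatic ring.

Going by the values given here, no two measured compounds differ in one place alone, so the data offer no direct precedent for this change. Nothing shown points to a direction, and no step beyond the usual scatter is expected in this assay. This expectation rests on compound 1, whose reading of > 30000 nM is a limit, so compound 4 may also return only a limit. The expected step of an at least 1.2-fold lower number from compound 1 to compound 4 (0.07 log units; that floor lies within the scatter) is an estimate and remains uncertain. For compound 4 the estimated value is 25000 nM, with an expected range from 8000 nM to 50000 nM.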

Compound 4, concentration for 50% growth inhibition: 25500 nM
Compound 4: the middle estimate sits 1.0-fold (0.01 log units) below what was measured, and the stated range covers the measured number.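

In this assay compound 1 gives > 30000 nM as a limit of the assay and not a number. Putting 4-chloro-2-methylphenyl in place of 3,4-dimethylphenyl on a nitrogen on an aromatic ring is the first change shown that is made in one place alone, and it gives an at least 1.1-fold lower number from compound 1 to compound 4 (0.07 log units; that floor lies within the scatter) while compound 4 returns a real reading of 25500 nM in this assay rather than a limit. Only a floor can be read for this step, and that floor does not establish a real gain at this position, because compound 1 rests on a limit: the limit of > 30000 nM in this assay, at which 2 of the 4 values shown sit.

The compounds shown do not separate the chlorine from the methyl, so it remains open what a phenyl ring carrying only the chlorine or only the methyl would give on this nitrogen. Going by these compounds, it also remains open whether an amine, a carboxylic acid or a morpholine on that phenyl ring would shift the reading on the same core, and how large the step from compound 1 truly is.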